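A Methyl Branch on the Acid Chain of Compound 1

The source may hold more compounds than are shown below. What is called first, only, known or untested is meant among the compounds shown, and "the series" means these compounds.

Of the compounds shown here, three have been measured in a functional assay on cells for agonist activity at Free fatty acid receptor 1 (Mus musculus), read by FLIPR and calcium flux, with a stated time of 5 min (a higher number here means a larger maximal response, a lower number a smaller maximal response), and a fourth awaits its number. Compound 1 `Cc1nn(-c2ccccn2)c2cc(-c3ccc(CCC(=O)O)cc3)ncc12` gives 86% in this assay. Compound 2 `Cc1nn(-c2ccccn2)c2cc(-c3ccc(CCC(=O)O)cc3Cl)ccc12` gives 102%, and compound 3 `O=C(O)CCc1ccc(-c2ccc3cnn(-c4ccccn4)c3c2)cc1` gives 106%. Of these three numbers, compound 1 stands lowest: the nearest is compound 2, whose number lies beyond the scatter above it, and the furthest is compound 3, also beyond the scatter. No two of the measured compounds differ in only one place, so no single step can be read from them.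

Compound 4 `Cc1nn(-c2ccccn2)c2cc(-c3ccc(C(C)CC(=O)O)cc3)ncc12` differs from compound 1 in one place: methyl in place of hydrogen on a saturated chain carbon bound to an aromatic carbon and a saturated chain carbon. The measured compounds say nothing about such a change to the chain, so the expectation rests on compound 1 alone. The step of a number 4 percentage points higher from compound 1 to compound 4 (within the scatter) is expected to be small, in no settled direction, and not beyond the scatter. Compound 4 is estimated at 90%, within a range from 70% to 108%.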

Compound 4, largest response reached (reported as efficacy), in percent of the reference or control that the assay uses: 50%
Compound 4: the middle estimate sits 40 percentage points above what was measured; measured number below the stated range.
By their numbers in this assay, from the lowest: compound 4; then compound 1; then compounds 2 and 3 (each within the scatter of the next).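

The chain carbon bound to an aromatic carbon and a saturated chain carbon proves sensitive to change: in this assay, methyl in place of hydrogen there gives a number 36 percentage points lower from compound 1 to compound 4 (beyond the scatter), a large step for 1 heavy atom. Among these compounds, the earlier compounds offered no step at all, so this is the first direct reading of the acid chain, and it shows that 2-carboxyethyl and 1-(carboxymethyl)ethyl are not interchangeable on the core of compound 1. No measurement at hand accounts for the drop.

As far as these compounds go, it remains open whether the same methyl would lower the response on the cores of compound 2 and compound 3. From the compounds shown here alone, it also remains open how an ethyl group, a fluorine atom or a hydroxyl group on this carbon would compare with methyl.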